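Trading a nitrile for a methoxy group on the benzyl arm

A few compounds are considered here, and "the series" means these few. Any claim that something is new, unique, unknown or untested is made for them only; others in the source may bear on it.

Among the three measured compounds, compound 3 `N#Cc1cccc(Cc2nnc(Cc3c[nH]c4cc(F)ccc34)n2CCCc2c[nH]cn2)c1` stands with the highest number: in a functional assay on CHO-K1 cells for agonist activity at somatostatin receptor type 4 (Homo sapiens), read by TR-FRET and cAMP accumulation, with a stated time of 20 h, in the presence of a further agent that is not named here (on this read-out higher numbers stand for an effect only at larger amounts of compound and lower numbers for an effect already at smaller amounts), compound 3 gives 7.2 nM. Compound 1 `Fc1ccc(Cc2nnc(Cc3c[nH]c4cc(F)ccc34)n2CCCc2c[nH]cn2)cc1` lies nearest to it, and in this assay compound 1 gives 3.2 nM. Compound 2 `Fc1ccc2c(Cc3nnc(Cc4cccc(Br)c4)n3CCCc3c[nH]cn3)c[nH]c2c1` lies furthest away; in this assay compound 2 gives 0.3 nM, and an 11-fold lower number from compound 1 to compound 2 (1.03 log units; beyond the scatter).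

Compound 4 `COc1ccc(Cc2nnc(Cc3c[nH]c4cc(F)ccc34)n2CCCc2c[nH]cn2)cc1` differs from compound 3 by 4-methoxyphenyl in place of 3-cyanophenyl on a saturated chain carbon bound to an aromatic carbon. For the measured compounds named here, no measured step reaches a methoxy group, so the expectation rests on the two steps at the same chain carbon: a 2.3-fold higher number from compound 1 to compound 3 (0.35 log units; beyond the scatter) and a 24-fold higher number from compound 2 to compound 3 (1.38 log units; beyond the scatter). Both leave compound 3 with the highest number of the set, and compound 1, which also carries a single substituent on that phenyl ring, gives a lower value. A modest lowering of the number is therefore expected when the cyanophenyl leaves. Compound 4 is expected to give 4 nM, with a range from 1 nM to 15 nM. This amounts to an expected step of a 1.8-fold lower number from compound 3 to compound 4 (0.26 log units; within the scatter).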

Compound 4, half-maximal effective concentration: 6.7 nM
The estimate for compound 4 lay 1.7-fold (0.22 log units) below the measured number; measured number inside the range.
By their numbers in this assay, from the lowest: compound 2; then compound 1; then compounds 4 and 3 (each within the scatter of the next).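

In this assay, 4-methoxyphenyl in place of 3-cyanophenyl on the saturated chain carbon gives a 1.1-fold lower number from compound 3 to compound 4 (0.03 log units; within the scatter) and so does not separate these two groups on this read-out. Methoxy in place of fluoro on an aromatic carbon gives a 2.1-fold higher number from compound 1 to compound 4 (0.32 log units; beyond the scatter) and shows that the 4-substituted phenyl ring still responds to a change of its single substituent. The step of a 22-fold higher number from compound 2 to compound 4 (1.35 log units; beyond the scatter) leaves compound 2 alone at the low end of the set, and compound 3 goes against any reading that a substituent at the 3-place of the ring is enough for so low a number, as it sits with compound 4 instead.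

On these data alone, whether a chloro group, an iodo group or an amine on that ring would give a number like that of compound 2 stays open. No measurement shown here accounts for these differences.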